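Aniline swap on the shared core: methoxy for bromine

The compounds below may be only part of what the source reports. "The series", "measured", "known", "first", "only" and "open" are said of these compounds alone.

The series keeps the core of compound 1 `CNC(=O)c1ccccc1Oc1nc(Nc2ccccc2F)ncc1Br` and varies the ring on the nitrogen on an aromatic ring. In a functional assay on MDA-MB-468 cells (Homo sapiens) for antiproliferative activity, read by MTT assay, with a stated time of 24 h (on this read-out higher numbers stand for weaker inhibition and lower numbers for stronger inhibition), compound 1 gives > 50000 nM, a limit of the assay and not a number; this is the limit of > 50000 nM in this assay, at which 1 of the 2 values shown sits. Compound 2 `CNC(=O)c1ccccc1Oc1nc(Nc2cccc(Br)c2)ncc1Br` gives 31900 nM, the only number shown. Within the data shown here, the one measured step, an at least 1.5-fold lower number from compound 1 to compound 2 (0.19 log units; that floor lies within the scatter), rests on that limit. Compound 3 `CNC(=O)c1ccccc1Oc1nc(Nc2ccccc2OC)ncc1Br` differs by 2-methoxyphenyl in place of 3-bromophenyl on a nitrogen on an aromatic ring. Among the measured compounds shown here, no measured step covers this exchange, so little beyond the scatter is expected. The expected step is a 1.4-fold higher number from compound 2 to compound 3 (0.15 log units; within the scatter). Compound 3 is estimated at 45000 nM, between 15000 nM and 150000 nM, with a limit again possible.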

Compound 3, half-maximal inhibitory concentration: > 50000 nM
Compound 3: a limit, no number (the forecaster's own chance of this, stated with the estimate: 45%); middle value at least 1.1-fold (0.04 log units) from the limit.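

The exchange on a nitrogen on an aromatic ring gives an at least 1.5-fold higher number from compound 2 to compound 3 (0.19 log units; that floor lies within the scatter), so no order between these two compounds can be claimed. In this assay compound 3 gives a limit and not a number, as compound 1 does, and the step between those two cannot be read. Compound 2 remains the only compound with a number, and the limit now holds most of the series: the limit of > 50000 nM in this assay, at which 2 of the 3 values shown sit.

From the compounds shown here alone, it remains open whether a phenyl ring bearing an amine or a carboxylic acid, or a longer chain in place of the ring, would give a value clear of the scatter from compound 2.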